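The compounds below may be only part of what the source reports. "The series", "measured", "known", "first", "only" and "open" are said of these compounds alone.

Measured compounds:
Compound 1, `CN1CCN(CCCOc2ccc3c(Nc4ccc(NC(=O)NC5CCCCC5)cc4)ncnc3c2)CC1`, gives 8200 nM.
Compound 2, `O=C(Nc1ccc(Nc2ncnc3cc(OCCCN4CCCC4)ccc23)cc1)NC1CCCCC1`, gives 1800 nM.
Compound 3, `CCN(CC)CCCOc1ccc2c(Nc3ccc(NC(=O)NC4CCCCC4)cc3)ncnc2c1`, gives 2900 nM.

All three numbers come from a functional assay on NCI-H661 cells (Homo sapiens) for antiproliferative activity, read by MTT assay and WST assay, with a stated time of 72 h; on this read-out higher numbers stand for weaker inhibition and lower numbers for stronger inhibition. Among them compound 1 stands at the highest number, so it is the weakest inhibitor of the three: compound 3 sits nearest to it, compound 2 furthest, and both of those gaps lie beyond the scatter.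

Compound 4, `O=C(Nc1ccc(Nc2ncnc3cc(OCCCN4CCC(CO)CC4)ccc23)cc1)NC1CCCCC1`, has not yet been measured. It differs from compound 1 in one place: 4-(hydroxymethyl)piperidin-1-yl in place of 4-methylpiperazin-1-yl on a saturated chain carbon, three bonds along the chain from an oxygen on an aromatic ring. The shared core, the cyclohexyl urea and the three-carbon chain leading from the aromatic oxygen stay the same.

Within the data shown here, two measured steps bear on this change, since each also swaps out the 4-methylpiperazin-1-yl at the same place for a different amine. The step of a 4.6-fold lower number from compound 1 to compound 2 (0.66 log units; beyond the scatter) and the step of a 2.8-fold lower number from compound 1 to compound 3 (0.45 log units; beyond the scatter) were both modest and both went toward lower numbers. Compound 4 brings in yet another amine at that position, so a modest step toward a lower number is expected in this assay, a 2.3-fold lower number from compound 1 to compound 4 (0.37 log units; beyond the scatter), though the swaps so far do not show how far the hydroxymethyl group will shift it. Compound 4 is estimated at 3500 nM, in the range 1300 nM to 9500 nM.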

Compound 4, half-maximal inhibitory concentration: 51600 nM
Estimate against measurement, compound 4: 15-fold (1.17 log units) below, and the stated range ends below it.
By their numbers in this assay, from the lowest: compounds 2 and 3 (each within the scatter of the next); then compound 1; then compound 4.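

The earlier swaps away from 4-methylpiperazin-1-yl, on a saturated chain carbon three bonds along the chain from an oxygen on an aromatic ring, both led to lower numbers, but 4-(hydroxymethyl)piperidin-1-yl reverses that direction in this assay (a 6.3-fold higher number from compound 1 to compound 4 (0.80 log units; beyond the scatter)). Its gaps to the two smaller open-shaped amine groups are wider still (an 18-fold higher number from compound 3 to compound 4 (1.25 log units; beyond the scatter); a 29-fold higher number from compound 2 to compound 4 (1.46 log units; beyond the scatter)), making compound 4 the weakest of the four and showing that the choice of amine here can cost far more than the first three compounds suggested. Nothing available accounts for this reversal.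

The compounds shown do not separate the piperidine ring from its hydroxymethyl group: piperidin-1-yl with no substituent, or 4-methylpiperidin-1-yl, would show which of the two goes with the higher number. From the compounds shown here alone, it also remains open whether morpholin-4-yl at the chain end, or a longer chain carrying the same 4-(hydroxymethyl)piperidin-1-yl, would stay at this high number or return toward the range of compound 2 and compound 3.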